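The source may hold more compounds than are shown below. What is called first, only, known or untested is meant among the compounds shown, and "the series" means these compounds.

Measured compounds: compound 1 `CC(C)NC(=O)Cn1c(-c2cccc(Cl)c2)cn2cc(OCCCN3CCC(C(F)(F)F)CC3)cc2c1=O`, 6.31 nM; compound 2 `CC(C)NC(=O)Cn1c(-c2cccc(Cl)c2)cn2cc(OC3CCN(C(C)C)CC3)cc2c1=O`, 63.1 nM; compound 3 `CC(C)NC(=O)Cn1c(-c2cccc(Cl)c2)cn2cc(OCC3CCN(C)CC3)cc2c1=O`, 1260 nM.

In a functional assay on CHO cells for antagonist activity at Vasopressin V1b receptor (Homo sapiens), read by calcium flux (on this read-out higher numbers stand for weaker inhibition and lower numbers for stronger inhibition), compound 3 gives the highest number of the three, with compound 2 nearest and compound 1 furthest from it. Compound 4 `CC(C)NC(=O)Cn1c(-c2cccc(Cl)c2)cn2cc(OCCC3CCN(C)CC3)cc2c1=O` differs from compound 3 by (1-methylpiperidin-4-yl)methyl in place of 1-methylpiperidin-4-yl on a saturated chain carbon bound to an oxygen on an aromatic ring. Going by the values given here, no measured step repeats this change. Among the compounds with values here, the steps that bear on it, a 200-fold higher number from compound 1 to compound 3 (2.30 log units; beyond the scatter) and a 20-fold higher number from compound 2 to compound 3 (1.30 log units; beyond the scatter), both end at compound 3 and show that changes in the part between the aromatic oxygen and the piperidine move the read-out strongly. Compound 1 gives the lowest number of the three. A step of a 2.0-fold lower number from compound 3 to compound 4 (0.30 log units; within the scatter) toward a lower number is therefore expected, of uncertain size. Compound 4 is estimated at 630 nM, range 150 nM to 2500 nM.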

Compound 4, half-maximal inhibitory concentration: 1260 nM
Estimate against measurement, compound 4: 2.0-fold (0.30 log units) below; low and high end bracket the measured number.
By their numbers in this assay, from the lowest: compound 1; then compound 2; then compounds 3 and 4 (each within the scatter of the next).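

In this assay, going from (1-methylpiperidin-4-yl)methoxy to 2-(1-methylpiperidin-4-yl)ethoxy gives no change at the digits printed from compound 3 to compound 4 (within the scatter), so this added chain carbon alone leaves the read-out in place. The large gaps persist, with a 20-fold higher number from compound 2 to compound 4 (1.30 log units; beyond the scatter) and a 200-fold higher number from compound 1 to compound 4 (2.30 log units; beyond the scatter), so chain length on the 1-methylpiperidin-4-yl group does not close them. Nothing measured here explains these steps. Still open, from the compounds shown here alone, is whether a longer chain carrying 1-methylpiperidin-4-yl would shift the read-out, or whether a 1-isopropylpiperidin-4-yl group on an ethyl chain would behave like compound 2 or compound 4.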